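Methoxy to hydroxy: two matched pairs in one series

A few compounds are considered here, and "the series" means these few. Any claim that something is new, unique, unknown or untested is made for them only; others in the source may bear on it.

Compound 1 `COc1cc(-c2nn(-c3cccc(NC(=O)Nc4cc(C(F)(F)F)cc(C(F)(F)F)c4)c3)cc2-c2ccncc2)ccc1Cl` gives 250 nM in a functional assay on PC-3 cells (Homo sapiens) for inhibition, read by sulforhodamine B assay, with a stated time of 48 h (on this read-out lower numbers stand for stronger inhibition and higher numbers for weaker inhibition), and stands lowest of the three measured numbers. Compound 2 `COc1cc(-c2nn(-c3cccc(NC(=O)Nc4ccc(Cl)c(Cl)c4)c3)cc2-c2ccncc2)ccc1Cl` gives 550 nM in this assay; the difference between the cores of compound 1 and compound 2 is not broken down here. Compound 3 `O=C(Nc1cccc(-n2cc(-c3ccncc3)c(-c3ccc(Cl)c(O)c3)n2)c1)Nc1ccc(Cl)c(Cl)c1` gives 830 nM in this assay. Compound 3 differs from compound 2 by hydrogen in place of methyl on an oxygen on an aromatic ring, and that change gave a 1.5-fold higher number from compound 2 to compound 3 (0.18 log units; within the scatter). Compound 4 `O=C(Nc1cccc(-n2cc(-c3ccncc3)c(-c3ccc(Cl)c(O)c3)n2)c1)Nc1cc(C(F)(F)F)cc(C(F)(F)F)c1` has not been measured; it differs from compound 1 by hydrogen in place of methyl on an oxygen on an aromatic ring, the same change at the same place as the earlier pair. Compound 4 is expected near 380 nM in this assay. Among the measured compounds shown here, the expected step is a 1.5-fold higher number from compound 1 to compound 4 (0.18 log units; within the scatter), resting on the single earlier instance a 1.5-fold higher number from compound 2 to compound 3 (0.18 log units; within the scatter). The estimated range for compound 4 runs from 190 nM to 800 nM.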

Compound 4, half-maximal inhibitory concentration: 320 nM
Beside the measured number, compound 4's estimate is 1.2-fold (0.07 log units) above it, within the range that was stated.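

Methoxy to hydroxy in this assay gave a 1.3-fold higher number from compound 1 to compound 4 (0.11 log units; within the scatter), a step within the scatter on the core of compound 1, as on the core of compound 2. The two pairs agree: the same change on two cores in this assay, a 1.5-fold higher number (0.18 log units; within the scatter) from compound 2 to compound 3 and a 1.3-fold higher number (0.11 log units; within the scatter) from compound 1 to compound 4, 1.2-fold (0.07 log units) apart, within the scatter of two such steps. This shows that the change carried from one core to the other without a step beyond the scatter, but neither step shows a clear effect of the change, and two pairs say nothing about cores outside these four compounds.

Still open, as far as these compounds go, is how an amine or a longer alkoxy chain such as ethoxy in place of the methoxy would read in this assay. Also open, from the compounds shown here alone, is whether the same change would hold with a group other than chloro on the ring.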